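A few compounds are considered here, and "the series" means these few. Any claim that something is new, unique, unknown or untested is made for them only; others in the source may bear on it.

Of the compounds shown here, three built on one shared core have been tested in a functional assay on the whole organism with Rattus norvegicus as the target, with a stated time of 4 h, at a dose of 40 mg/kg by the intraperitoneal route; on this read-out lower numbers stand for less inhibition and higher numbers for more inhibition at the one dose given (going by the name of the read-out). Compound 1 `Cc1cn2cccc(OCc3ccccc3)c2n1` gives 62%. Compound 2 `Cc1nc2c(OCc3ccccc3)cccn2c1CO` gives 99%. Compound 3 `Cc1nc2c(OCc3ccccc3)cccn2c1CS(C)(=O)=O` gives 61%, the lowest of the three numbers, although its gap to compound 1 lies within the scatter; only compound 2 stands clearly apart from it, as a number 38 percentage points lower from compound 2 to compound 3 (beyond the scatter) shows.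

Compound 4 `COC(=O)Cc1c(C)nc2c(OCc3ccccc3)cccn12` has not yet been measured. It differs from compound 3 at a single place: methoxycarbonyl in place of methylsulfonyl on a saturated chain carbon bound to an aromatic carbon. Among the compounds with values here, two measured steps touch this position. a number 1 percentage points lower from compound 1 to compound 3 (within the scatter) shows that attaching the (methylsulfonyl)methyl group to the core left the number essentially unchanged. a number 38 percentage points lower from compound 2 to compound 3 (beyond the scatter) shows that exchanging hydroxy for methylsulfonyl on that saturated chain carbon moved the number far downward. No measured pair sets methylsulfonyl against methoxycarbonyl directly, and the leaving and entering groups match in donors and acceptors as counted above, so there is no measured reason to expect a large move in either direction. Compound 4 is therefore expected to differ from compound 3 by a number 1 percentage points lower from compound 3 to compound 4 (within the scatter), a step within the scatter. The estimate for compound 4 in this assay is 60%, with a range from 35% to 85%.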

Compound 4, a percentage reported as inhibition, in the whole organism at one dose (the size of the read-out at that dose, not a potency): 23%
Beside the measured number, compound 4's estimate is 37 percentage points above it; measured number below the stated range.
By their numbers in this assay, from the lowest: compound 4; then compounds 3 and 1 (each within the scatter of the next); then compound 2.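

The methylsulfonyl and methoxycarbonyl groups match in heavy atoms, hydrogen-bond donors and acceptors as counted, yet on this saturated chain carbon they are not interchangeable in this assay, as a number 38 percentage points lower from compound 3 to compound 4 (beyond the scatter) shows. Until now, adding a group to the core at this place had either raised the number or left it within the scatter, whereas a number 39 percentage points lower from compound 1 to compound 4 (beyond the scatter) shows that such an addition can also lower it, so the same place can move the read-out in either direction. The widest gap at this place is now a number 76 percentage points lower from compound 2 to compound 4 (beyond the scatter), which means that changing only the group on this chain carbon spans much of the range seen in the series.

Nothing available here explains why these groups give such different numbers, so the cause of the fall remains unknown. The compounds shown also leave open how a carboxylic acid or an amide on the same saturated chain carbon would read, and whether a longer chain ending in hydroxy would keep the high number of compound 2 99%.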